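A few compounds are considered here, and "the series" means these few. Any claim that something is new, unique, unknown or untested is made for them only; others in the source may bear on it.

Compound 1 `N[C@H]1CC[C@H](Nc2c(C(=O)NCc3ccc(Oc4ccccc4)cc3)nc(Br)c3cccnc23)CC1` gives "not determined" (no result reported) in a functional assay on SK-BR-3 cells (Homo sapiens) for cytotoxicity, read by MTT assay, with a stated time of 72 h; on this read-out lower numbers stand for stronger inhibition and higher numbers for weaker inhibition; its standing on that read-out is open. Among the measured compounds shown here, the one measured compound of the group, compound 2 `Nc1ccc(Nc2c(C(=O)NCc3ccc(F)cc3)nc(Br)c3cccnc23)cc1`, gives 4000 nM in this assay. Compound 3 `N[C@H]1CC[C@H](Nc2c(C(=O)NCc3ccccc3)nc(Br)c3cccnc23)CC1` differs from compound 1 by hydrogen in place of phenoxy on an aromatic carbon. No step between measured compounds is shown for this change, so nothing here says how large it should be or which way it should go; a step that stays within the scatter of this assay is as plausible as a step beyond it. Compound 3 is expected to give about 4000 nM in this assay, within a broad range from 800 nM to 20000 nM.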

Compound 3, half-maximal inhibitory concentration: 8000 nM
Beside the measured number, compound 3's estimate is 2.0-fold (0.30 log units) below it, and the stated range covers the measured number.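

In this assay no step can be read between compound 1 and compound 3. How replacing phenoxy with hydrogen shifts the value stays open, and no evidence shown bears on this result.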